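The source may hold more compounds than are shown below. What is called first, only, known or untested is meant among the compounds shown, and "the series" means these compounds.

Working notes on the series.

Among the compounds with values here, compound 2 `CC(C)(C)c1[nH]cnc1/C=c1\[nH]c(=O)/c(=C/c2ccccc2)nc1OCOC(=O)CCCc1cn([C@@H](CC(=O)O)C(=O)O)nn1` is the longer-lived of the two compounds measured so far: in an ADME assay for pharmacokinetics, with liver carboxylesterase (Sus scrofa) as the target, read by HPLC (on this read-out lower numbers stand for a shorter-lived compound and higher numbers for a longer-lived compound), compound 2 gives 12 h, the higher of the two numbers. Within the data shown here, its only measured neighbour is compound 1 `CC(C)(C)c1[nH]cnc1/C=c1\[nH]c(=O)/c(=C/c2ccccc2)nc1OCOC(=O)CCCc1cn([C@@H](CO)C(=O)O)nn1`, which in this assay gives 1 h; the step of a 12-fold higher number from compound 1 to compound 2 (1.08 log units; beyond the scatter) is the single step recorded, and it is large.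

Compound 3 `CC(C)(C)c1[nH]cnc1/C=c1\[nH]c(=O)/c(=C/c2ccccc2)nc1OCOC(=O)CCCc1cn([C@@H](CCC(=O)O)C(=O)O)nn1` is not yet measured. It differs from compound 2 by carboxymethyl in place of carboxy on a saturated chain carbon, two bonds along the chain from an aromatic nitrogen and a carbonyl carbon. Among the measured compounds shown here, this is a different kind of change from the one measured step: there a hydroxy became a carboxy at that chain carbon, whereas here the carboxy already present is moved out by one carbon, so that the difference cut one bond further out reads carboxymethyl to 2-carboxyethyl. For the measured compounds named here, no measured step bears directly on such a chain extension, and nothing in the two numbers points in either direction for it.

The working expectation for compound 3 is therefore a step of no change at the digits printed from compound 2 to compound 3 (within the scatter) that does not go beyond the scatter. Compound 3 is estimated at 12 h in this assay, with a range from 4 h to 30 h.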

Compound 3, half-life in the liver carboxylesterase assay: 5.4 h
Compound 3: the middle estimate sits 2.2-fold (0.35 log units) above what was measured; measured number inside the range.
By their numbers in the liver carboxylesterase assay, from the lowest: compound 1; then compound 3; then compound 2.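

Within the data shown here, the chain length of the acid group on this saturated chain carbon matters in the liver carboxylesterase assay: with the carboxy of the earlier compounds extended to carboxymethyl, the read-out shows a 2.2-fold lower number from compound 2 to compound 3 (0.35 log units; beyond the scatter), so the large rise seen on going from hydroxy to carboxy does not simply carry over to the longer side chain. The extended group still stands clear of hydroxy, with carboxymethyl in place of hydroxy at the same carbon giving a 5.4-fold higher number from compound 1 to compound 3 (0.73 log units; beyond the scatter), so part of that rise is kept and part is lost. In a physicochemical assay for solubility, read by HPLC, with a stated time of 15 min (a lower number here means a less soluble compound, a higher number a more soluble compound), compound 2 gives > 100000 ug/mL, which is a limit of the assay and not a number. In the physicochemical assay compound 3 gives > 100000 ug/mL, which is also a limit of the assay and not a number. In the physicochemical assay the step from compound 2 to compound 3 cannot be read, since both values are limits of the assay and not numbers: the limit of > 100000 ug/mL in the physicochemical assay, at which 2 of the 2 values shown sit.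

Still open, as far as these compounds go, is whether a longer chain carrying the carboxylic acid on this carbon would lower the half-life further or level off, given that the order so far rests on three compounds only. Also open, from the compounds shown here alone, is where an amine or a primary amide on the same carbon would fall relative to the hydroxy and the carboxylic acid groups.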